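Hydroxypiperidine for diisopropylamine in a pyrazoline amide

The source may report more compounds than this note shows. Statements on the series, on what has been measured and on what is new or still open speak of the compounds shown alone.

Measured compounds:
compound 1, `CC1=NN(C(=O)CCc2ccccc2)C(c2cc(Br)cc(Br)c2O)C1`, 11300 nM
compound 2, `CC(=O)Oc1ccccc1C1CC(C)=NN1C(=O)CN(C(C)C)C(C)C`, 24500 nM

Of the compounds shown here, two have been tested in a functional assay on PC-3 cells (Homo sapiens) for cytotoxicity, read by MTT assay, with a stated time of 48 h; on this read-out lower numbers stand for stronger inhibition and higher numbers for weaker inhibition. Compound 1, with its two bromine atoms on the phenol and a phenylpropanoyl group on the ring nitrogen, gives 11300 nM. Compound 2, carrying an acetoxyphenyl group and a (diisopropylamino)acetyl chain, gives 24500 nM, the highest of the two numbers; compound 1 sits at a lower number, by a gap that lies beyond the scatter. Since these two differ in several places at once, their values show only that both act in the micromolar range.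

Compound 3, `CC(=O)Oc1ccccc1C1CC(C)=NN1C(=O)CN1CCC(O)CC1`, keeps the core of compound 2 and changes one thing: 4-hydroxypiperidin-1-yl in place of diisopropylamino on a saturated chain carbon bound to a carbonyl carbon. Among the measured compounds shown here, no measured pair differs in that single place, so there is no step to lean on. The change keeps the same count of heavy atoms and adds a hydroxyl, and the author expects no step beyond the scatter, a 1.1-fold higher number from compound 2 to compound 3 (0.03 log units; within the scatter). For compound 3 the author therefore estimates 26000 nM, within a range from 9000 nM to 75000 nM.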

Compound 3, half-maximal inhibitory concentration: 25600 nM
Compound 3: middle estimate off by 1.0-fold (0.01 log units), on the high side, within the range that was stated.
By their numbers in this assay, from the lowest: compound 1; then compounds 2 and 3 (each within the scatter of the next).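

In this assay, among the compounds shown here, the exchange of diisopropylamino for 4-hydroxypiperidin-1-yl on a saturated chain carbon bound to a carbonyl carbon gives a 1.0-fold higher number from compound 2 to compound 3 (0.02 log units; within the scatter) and provides the first comparison in this set that isolates a single place. At this place on the core of compound 2, a group with no ring and no hydrogen-bond donor and a group with one six-membered non-aromatic ring and one hydrogen-bond donor therefore give values that cannot be told apart, so this one pair shows no sensitivity to the change. No supporting finding is available to explain this outcome.

One open question is whether the hydroxyl matters on its own, which the unsubstituted piperidin-1-yl group would test, and whether other groups at this place, such as morpholin-4-yl, a piperazine or a carboxylic acid, would also stay within the scatter of compound 2. As far as these compounds go, it also remains open whether the same exchange would read alike with a group other than the acetoxy group on the phenyl ring, since this single pair speaks only for the core it shares.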